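This account rests on a few compounds, and the source may have more. Where it says the series, first, only, none or still open, it means among the compounds named here.

Of the compounds shown here, three have been measured in a physicochemical assay for lipophilicity, at pH 7.4; a higher number here means a more lipophilic compound, a lower number a more polar compound: compound 1 (`CCC(=O)N1C[C@@H]2[C@H](C1)[C@H]2NC(=O)c1cc(C(=O)NC)c2c(c1)[C@H](c1ccccc1)CO2`) gives 3.4, compound 2 (`CNC(=O)c1cc(C(=O)N[C@H]2C[C@@H]2C)cc2c1OC[C@@]2(C)c1ccccc1`) gives 4.7 and compound 3 (`CNC(=O)c1cc(C(=O)N[C@H]2C[C@@H]2C)cc2c1OC[C@@]2(CO)c1ccccc1`) gives 3.3. Compound 2 stands highest of the three, and its gap to each of the others lies beyond the scatter. Compound 4 (`CNC(=O)c1cc(C(=O)N[C@H]2[C@@H]3C[C@@H](O)C[C@@H]32)cc2c1OC[C@@]2(C)c1ccccc1`) differs from compound 2 on the amide-type nitrogen: a group of 7 heavy atoms (6 carbon, 1 oxygen; one three-membered non-aromatic ring of carbon only, one five-membered non-aromatic ring of carbon only) in place of a group of 4 heavy atoms (4 carbon; one three-membered non-aromatic ring of carbon only), on an amide-type nitrogen. For the measured compounds named here, the only measured step that bears on this change is a number 1.40 log units lower from compound 2 to compound 3 (beyond the scatter), which swaps hydrogen for hydroxy. Going by the values given here, the entering group also holds oxygen and a hydrogen-bond donor, but no measured step covers its added carbon. A smaller fall than that one is therefore expected: a number 0.80 log units lower from compound 2 to compound 4 (beyond the scatter). Compound 4 is estimated at 3.9, within an expected range of 3.4 to 4.4.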

Compound 4, distribution coefficient: 3.3
Estimate against measurement, compound 4: 0.60 log units above, and the stated range ends above it.
By their numbers in this assay, from the lowest: compounds 3, 4 and 1 (each within the scatter of the next); then compound 2.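

On the amide-type nitrogen, replacing 2-methylcyclopropyl with the larger hydroxy-bearing ring group gives a number 1.40 log units lower from compound 2 to compound 4 (beyond the scatter) in this assay, so this position can carry a large change. That step is printed at the same size as a number 1.40 log units lower from compound 2 to compound 3 (beyond the scatter), although the entering group here also brings added carbon. Nothing measured here accounts for the size of this fall. The compounds shown leave open how the step divides between the hydroxy and the ring carbons, and how an amine or a carboxylic acid in place of that hydroxy would read.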